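A few compounds are considered here, and "the series" means these few. Any claim that something is new, unique, unknown or untested is made for them only; others in the source may bear on it.

Of the compounds shown here, two have been tested in a functional assay on MCF7 cells (Homo sapiens) for inhibition, read by MTT assay, with a stated time of 72 h (on this read-out lower numbers stand for stronger inhibition and higher numbers for weaker inhibition), so far. Compound 1 `O=C1Nc2cccc(Cl)c2/C1=N/NC(=S)N1CCN(c2ccccc2)CC1` gives 52100 nM in this assay. Compound 2 `Cc1ccc(N2CCN(C(=S)N/N=C3\C(=O)Nc4ccc(Cl)cc43)CC2)c(C)c1` gives 10800 nM in this assay, the lower of the two numbers; the gap to compound 1 lies beyond the scatter. Compound 1 and compound 2 differ from each other in more than one place. Their two values alone therefore cannot be tied to a single change.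

The step considered here leads from compound 2 to compound 3 `O=C1Nc2ccc(Cl)cc2/C1=N/NC(=S)N1CCN(c2ccccc2F)CC1`, which has not yet been measured in this assay. The change is 2-fluorophenyl in place of 2,4-dimethylphenyl on an amine nitrogen in a ring. For the measured compounds named here, no measured pair in the data isolates a change of this kind, so the expectation rests on compound 2 alone and on the observation that compound 1, carrying a phenyl group without methyl groups at this position, gives 52100 nM. On that basis compound 3 is expected to fall somewhat weaker than compound 2, a step of a 1.9-fold higher number from compound 2 to compound 3 (0.27 log units; within the scatter), though within a band that also allows no change beyond the scatter. The estimate for compound 3 in this assay is 20000 nM, with a range from 7000 nM to 60000 nM.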

Compound 3, half-maximal inhibitory concentration: 15200 nM
The estimate for compound 3 lay 1.3-fold (0.12 log units) above the measured number; the measured number falls inside the stated range.
By their numbers in this assay, from the lowest: compounds 2 and 3 (each within the scatter of the next); then compound 1.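

For the compounds shown here, compound 2 and compound 3 form the first pair that differs in one place, and in this assay the exchange of 2,4-dimethylphenyl for 2-fluorophenyl on the amine nitrogen in the ring gives a 1.4-fold higher number from compound 2 to compound 3 (0.15 log units; within the scatter). At this position, therefore, the two substituted aromatic rings cannot be told apart on this read-out, which the earlier pair, differing in more than one place, could not show. The data at hand offer no measurement that would explain this result.

Going by these compounds alone, the pair shows only that these two groups read alike on the shared core, so it says nothing about how far this position tolerates a group of a different kind, such as a carboxylic acid or an amine on the aromatic ring, or a longer chain in place of that ring on the same nitrogen. From the compounds shown here alone, the value of compound 1 also remains untied to any single change, since it differs from compound 2 and from compound 3 in more than one place, and the separate contribution of its phenyl group stays open.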